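Carboxyethyl in place of the aryl ester on the shared core

The source may report more compounds than this note shows. Statements on the series, on what has been measured and on what is new or still open speak of the compounds shown alone.

Compound 1 `CCCCCCCCc1ccc(OCC(=O)Cn2nnc(-c3cccc(C(=O)OC)c3)n2)cc1` is the reference point of this small set. Within the data shown here, in an assay on microsomes from brain for inhibition of Fatty-acid amide hydrolase 1 (Rattus norvegicus), read by fluorescence and HPLC, with a stated time of 60 min (on this read-out lower numbers stand for stronger inhibition and higher numbers for weaker inhibition), compound 1 gives 34 nM, the lowest of the three numbers measured so far. Compound 2 `CCCCCCCCc1ccc(OCC(=O)Cn2nnc(-c3cccc(S(=O)(=O)N(C)C)c3)n2)cc1` gives 420 nM, and compound 3 `CCCCCCCCc1ccc(OCC(=O)Cn2nnc(Cc3ccccc3)n2)cc1` gives 66 nM. The step of a 12-fold higher number from compound 1 to compound 2 (1.09 log units; beyond the scatter) is the one clear shift in the set, whereas the step of a 1.9-fold higher number from compound 1 to compound 3 (0.29 log units; within the scatter) stays within the scatter; the step of a 6.4-fold lower number from compound 2 to compound 3 (0.80 log units; beyond the scatter) runs back toward the lower numbers.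

Compound 4 `CCCCCCCCc1ccc(OCC(=O)Cn2nnc(CCC(=O)O)n2)cc1` has not yet been measured. It differs from compound 1 in one place: 2-carboxyethyl in place of 3-(methoxycarbonyl)phenyl on an aromatic carbon. Among the measured compounds shown here, two measured steps bear on this. The step of a 1.9-fold higher number from compound 1 to compound 3 (0.29 log units; within the scatter) shows that the substituted aromatic ring can be exchanged for a benzyl group without a shift beyond the scatter, so the aromatic ring itself is not essential on these numbers. The step of a 12-fold higher number from compound 1 to compound 2 (1.09 log units; beyond the scatter) shows that exchanging the methoxycarbonyl for a different group on that ring costs a large step. Compound 4 goes further than either: the ring is gone entirely, and a hydrogen-bond donor enters. A modest weakening is therefore expected, a 5.9-fold higher number from compound 1 to compound 4 (0.77 log units; beyond the scatter), with wide uncertainty. Compound 4 is estimated at 200 nM, within a range of 50 nM to 800 nM.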

Compound 4, half-maximal inhibitory concentration: 30 nM
Beside the measured number, compound 4's estimate is 6.7-fold (0.82 log units) above it; measured number outside the range, below it.
By their numbers in this assay, from the lowest: compounds 4, 1 and 3 (each within the scatter of the next, the first and the last beyond it); then compound 2.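

At this position, on an aromatic carbon of the five-membered aromatic ring with 4 nitrogen, the 3-(methoxycarbonyl)phenyl group can be replaced by 2-carboxyethyl with no shift beyond the scatter in this assay (a 1.1-fold lower number from compound 1 to compound 4 (0.05 log units; within the scatter)), so neither the aromatic ring nor the methyl ester is required in this pair. The same open-chain group also compares favourably with the benzyl group (a 2.2-fold lower number from compound 3 to compound 4 (0.34 log units; beyond the scatter)) and with the 3-(dimethylsulfamoyl)phenyl group (a 14-fold lower number from compound 2 to compound 4 (1.15 log units; beyond the scatter)), which shows that a ring at this position is not needed for the low numbers seen with compound 1 and compound 4. No measurement shown here explains why these different groups give such similar or such different numbers.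

Going by these compounds, it remains open whether the result depends on the carboxylic acid itself or on the chain that carries it; a methyl ester or primary amide on the same chain, or a longer chain ending in a carboxylic acid, would separate these two readings. Also open, on these data alone, is how a 3-carboxyphenyl group would compare with the 3-(methoxycarbonyl)phenyl group of compound 1 on the shared core.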